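Cyclopropyl for Ethyl on Two Related Cores

A few compounds are considered here, and "the series" means these few. Any claim that something is new, unique, unknown or untested is made for them only; others in the source may bear on it.

The measured compounds, with their values in an ADME assay (Canis lupus familiaris, strain Beagle) for pharmacokinetics; a lower number here means that more of the compound stays in the plasma, a higher number that more of the compound sits outside the plasma:
compound 1, `CCn1c(-c2cnc(C)nc2)nc2c(O[C@H]3CCN(C(=O)C4CC4)C3)ncnc21`: 0.7 L/kg
compound 2, `CCC(=O)N1CC[C@H](Oc2ncnc3c2nc(-c2cnc(C)nc2)n3CC)C1`: 2.7 L/kg
compound 3, `CCC(=O)N1CC[C@H](Nc2ncnc3c2nc(-c2cnc(C)nc2)n3CC)C1`: 2.7 L/kg

Compound 4, `CCn1c(-c2cnc(C)nc2)nc2c(N[C@H]3CCN(C(=O)C4CC4)C3)ncnc21`, has not yet been measured. Compound 3 and compound 2 give the same number at the digits reported, and together they stand highest of the three; the difference between their two cores is not broken down here. Compound 1 differs from compound 2 by one change, (cyclopropyl in place of ethyl on a carbonyl carbon), and that change gave a 3.9-fold lower number from compound 2 to compound 1 (0.59 log units; beyond the scatter). Compound 4 differs from compound 3 by cyclopropyl in place of ethyl on a carbonyl carbon, the same change at the same place. For the measured compounds named here, only one such step is known, so the expectation rests on compound 1 alone, whose step from compound 2 is a 3.9-fold lower number from compound 2 to compound 1 (0.59 log units; beyond the scatter). On that basis the step from compound 3 to compound 4 is expected to be about a 3.4-fold lower number from compound 3 to compound 4 (0.53 log units; beyond the scatter). Compound 4 is therefore estimated to give 0.8 L/kg in this assay, with a likely range from 0.4 L/kg to 1.6 L/kg.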

Compound 4, volume of distribution: 1.8 L/kg
Estimate against measurement, compound 4: 2.3-fold (0.35 log units) below; measured number above the stated range.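

In this assay, cyclopropyl in place of ethyl on a carbonyl carbon gives a 1.5-fold lower number from compound 3 to compound 4 (0.18 log units; within the scatter), a step that on its own cannot be told apart from repeated measurement. Set beside the earlier step on the other core, it does not differ by more than two such steps may scatter: the same change on two cores in this assay, a 3.9-fold lower number (0.59 log units; beyond the scatter) from compound 2 to compound 1 and a 1.5-fold lower number (0.18 log units; within the scatter) from compound 3 to compound 4, 2.6-fold (0.41 log units) apart, within the scatter of two such steps. For the compounds shown here, these two steps therefore give no ground for saying that the core alters the effect of this change, but they do not establish that it carries over at a fixed size either, as only the step on the core of compound 1 stands clear of the scatter, and two steps are too few to fix a size.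

On these data alone, it remains open how a larger ring such as cyclobutyl, or a longer chain such as butyl, would read in that same place on the carbonyl carbon. As far as these compounds go, how an amine or a carboxylic acid carried there would read in this assay is equally open.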